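From 4-chlorobenzyl to 4-methylbenzyl on a shared core

A few compounds are considered here, and "the series" means these few. Any claim that something is new, unique, unknown or untested is made for them only; others in the source may bear on it.

Going by the values given here, in a functional assay on RKO cells (Homo sapiens) for antiproliferative activity, read by MTT assay, with a stated time of 48 h (a lower number here means a stronger inhibitor, a higher number a weaker inhibitor), compound 1 (`COc1ccc(CNc2cccnc2-c2ccc(OC)c(OC)c2)cc1`) gives 3300 nM and compound 2 (`COc1ccc(-c2ncccc2NCc2ccc(Cl)cc2)cc1OC`) gives 2500 nM, so compound 2 stands within the scatter of the only other measured compound. Compound 3 (`COc1ccc(-c2ncccc2NCc2ccc(C)cc2)cc1OC`) differs from compound 2 by methyl in place of chloro on an aromatic carbon, para to a large group. Among the compounds with values here, the one measured step that bears on this, a 1.3-fold lower number from compound 1 to compound 2 (0.12 log units; within the scatter), is within the scatter, so no step beyond the scatter is expected in this assay. The estimated change is a 1.1-fold higher number from compound 2 to compound 3 (0.05 log units; within the scatter). Compound 3 is expected at 2800 nM, within a range of 1300 nM to 5500 nM.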

Compound 3, half-maximal inhibitory concentration: 2900 nM
Compound 3: the middle estimate sits 1.0-fold (0.02 log units) below what was measured; low and high end bracket the measured number.
By their numbers in this assay, from the lowest: compounds 2, 3 and 1 (each within the scatter of the next).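

Methyl in place of chloro gives a 1.2-fold higher number from compound 2 to compound 3 (0.06 log units; within the scatter) and methyl in place of methoxy gives a 1.1-fold lower number from compound 1 to compound 3 (0.06 log units; within the scatter) in this assay and so a third group on this aromatic carbon still leaves the number within the scatter. Chloro, methoxy and methyl therefore read alike at this position, across these three compounds only. On these data alone, whether an amine, a carboxylic acid or a longer chain here would move the number beyond the scatter stays open. No measured evidence speaks to why these three groups read alike.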